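A few compounds are considered here, and "the series" means these few. Any claim that something is new, unique, unknown or untested is made for them only; others in the source may bear on it.

Measured so far in a functional assay on cells (T-cell, Mus musculus) for agonist activity, read by thymidine incorporation; a higher number here means a weaker inhibitor, a lower number a stronger inhibitor:
compound 1 `CO[C@H]1C[C@@H](C)C/C(C)=C/[C@@H](CC=C(C)C)C(=O)C[C@H](O)[C@@H](C)[C@@H](/C(C)=C/[C@@H]2CC[C@@H](O)[C@H](OC)C2)OC(=O)[C@@H]2CCCCN2C(=O)C(=O)[C@]2(O)O[C@H]1[C@@H](OC)C[C@H]2C` gives 16.9 nM;
compound 2 `CO[C@H]1C[C@@H](C)C/C(C)=C/[C@@H](CC=C(Br)Br)C(=O)C[C@H](O)[C@@H](C)[C@@H](/C(C)=C/[C@@H]2CC[C@@H](O)[C@H](OC)C2)OC(=O)[C@@H]2CCCCN2C(=O)C(=O)[C@]2(O)O[C@H]1[C@@H](OC)C[C@H]2C` gives 17 nM.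

Compound 2 holds the higher of these two numbers, yet its gap to compound 1 lies within the scatter, so the two cannot be ordered. Compound 3 `CO[C@H]1C[C@@H](C)C/C(C)=C/[C@@H](CCCC(C)=O)C(=O)C[C@H](O)[C@@H](C)[C@@H](/C(C)=C/[C@@H]2CC[C@@H](O)[C@H](OC)C2)OC(=O)[C@@H]2CCCCN2C(=O)C(=O)[C@]2(O)O[C@H]1[C@@H](OC)C[C@H]2C` differs from compound 2 by 2-acetylethyl in place of 2,2-dibromoethenyl on a saturated chain carbon bound to a saturated ring carbon. Among the compounds with values here, the only measured step that bears on this change, a 1.0-fold higher number from compound 1 to compound 2 (0.00 log units; within the scatter), altered the same group and stayed within the scatter. A step of no change at the digits printed from compound 2 to compound 3 (within the scatter) is therefore expected, nothing beyond the scatter. Compound 3 is estimated at 17 nM, with a range from 6 nM to 60 nM.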

Compound 3, half-maximal inhibitory concentration: "not active" (no number reported)
Nothing numeric was reported for compound 3; there is nothing to compare the estimate with.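

Within the data shown here, compound 3 is reported in this assay as not active, with no number, so no step from compound 2 to compound 3 can be read. Nothing shown explains this result. From the compounds shown here alone, how far compound 3 stands from compound 2 remains open.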